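The compounds below may be only part of what the source reports. "The series", "measured", "known", "first", "only" and "open" are said of these compounds alone.

Compound 3 `N#CC1=C(NCC(=O)N2CCCCC2)N(c2ccccc2)C(=O)N2CCCCC(N3CCCC3)C12` gives 53.5% in a functional assay on the whole organism (strain albino) for inhibition, with Rattus norvegicus as the target, read by paw edema, with stated times of 1 h and 3 h, at a dose of 20 mmol/kg by the intraperitoneal route; on this read-out higher numbers stand for a stronger effect at the one dose given and lower numbers for a weaker effect; on the numbers shown it sits together with compound 2 `N#CC1=C(NCC(=O)N2CCCC2)N(c2ccccc2)C(=O)N2CCCCC(N3CCCC3)C12`, which gives 56%, a gap within the scatter, and clearly apart from compound 1 `N#CC1=C(NCN2CCCCC2)N(c2ccccc2)C(=O)N2CCCCC(N3CCCC3)C12`, which gives 42.1%, with a number 11.4 percentage points higher from compound 1 to compound 3 (beyond the scatter). Compound 4 `COc1ccc(/C=N/C2=C(C#N)C3C(N4CCCC4)CCCCN3C(=O)N2c2ccccc2)cc1` differs from compound 3 in that (a group of 10 heavy atoms (8 carbon, 1 nitrogen, 1 oxygen; one six-membered aromatic ring of carbon only) in place of a group of 10 heavy atoms (7 carbon, 2 nitrogen, 1 oxygen; one six-membered non-aromatic ring with 1 hetero atom), on a double-bonded ring carbon). Going by the values given here, none of the measured steps bears closely on this change: a number 13.9 percentage points higher from compound 1 to compound 2 (beyond the scatter) and a number 2.5 percentage points lower from compound 2 to compound 3 (within the scatter) only vary the group on the saturated chain carbon or on the carbonyl carbon, whereas here the entire group on the double-bonded ring carbon is exchanged. Among the compounds with values here, with no guiding step, the change is expected to be modest, a number 6.5 percentage points lower from compound 3 to compound 4 (within the scatter). Compound 4 is therefore estimated at 47%, between 28% and 64%.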

Compound 4, a percentage reported as inhibition, in the whole organism at one dose (the size of the read-out at that dose, not a potency): 75.3%
Estimate against measurement, compound 4: 28.3 percentage points below; measured number outside the range, above it.
By their numbers in this assay, from the lowest: compound 1; then compounds 3 and 2 (each within the scatter of the next); then compound 4.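

In this assay, replacing the (((piperidin-1-yl)carbonyl)methyl)amino group on the double-bonded ring carbon with the group bearing an aromatic ring of carbon only gives a number 21.8 percentage points higher from compound 3 to compound 4 (beyond the scatter) and the same kind of exchange gives a number 19.3 percentage points higher from compound 2 to compound 4 (beyond the scatter) and also a number 33.2 percentage points higher from compound 1 to compound 4 (beyond the scatter) in the same direction. The earlier compounds shown here varied only the end of the amino chain, whereas these steps show that the whole group at this position can be exchanged with the number rising clear of all three.

On these data alone, whether the methoxy group on that aromatic ring contributes, or whether a chloro or nitro group there would give a similar number, remains open. Nothing available explains the rise.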